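Swapping the side chain of compound 3 for an ether

A few compounds are considered here, and "the series" means these few. Any claim that something is new, unique, unknown or untested is made for them only; others in the source may bear on it.

Compound 1 `NC(=O)c1cnc2ccc(-c3cccnc3)cc2c1NC1CCCCC1` gives 3.8
Compound 2 `NC(=O)c1cnc2ccc(-c3cccnc3)cc2c1NCC1CCCCC1` gives > 4.3 which is a limit of the assay
Compound 3 `C[C@@H](Nc1c(C(N)=O)cnc2ccc(-c3cccnc3)cc12)C1CCOCC1` gives 2.3

In a physicochemical assay for lipophilicity, using the shake flask method, measured as octanol-water partition, at pH 7.4 (on this read-out higher numbers stand for higher lipophilicity and lower numbers for lower lipophilicity), compound 3 gives 2.3 as the lower of the two true numbers. Compound 2 has only a limit. Compound 4 `CCC(CC)COc1c(C(N)=O)cnc2ccc(-c3cccnc3)cc12` replaces the side chain on the shared core (2-ethylbutoxy in place of (1-(oxan-4-yl)ethyl)amino on an aromatic carbon) and so gives up the 1-(oxan-4-yl)ethyl group. Two large measured steps bear on this, both ending at that group: a number 1.50 log units lower from compound 1 to compound 3 (beyond the scatter) from cyclohexyl, and a number at least 2.00 log units lower from compound 2 to compound 3 (beyond the scatter) from cyclohexylmethyl. The step of a number at least 0.50 log units higher from compound 1 to compound 2 (beyond the scatter) adds that the two groups without a ring oxygen also differ from each other. For the measured compounds named here, no measured step swaps the linking nitrogen for oxygen, and this widens the range. In this assay a large rise is therefore expected, with a number 1.60 log units higher from compound 3 to compound 4 (beyond the scatter) as the estimate. Compound 4 is estimated at 3.9 with 3.3 to 4.5 as the expected range.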

Compound 4, distribution coefficient: > 4.3
Compound 4: a limit, no number; the forecaster's own chance of this, stated with the estimate: 25%; middle value at least 0.40 log units from the limit.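

Until now, every group on this aromatic carbon was joined through nitrogen. Compound 4 shows that an open chain joined through oxygen, 2-ethylbutoxy, also gives a high reading in this assay, with a number at least 2.00 log units higher from compound 3 to compound 4 (beyond the scatter) and a number at least 0.50 log units higher from compound 1 to compound 4 (beyond the scatter). Compound 4 gives only a limit of the assay, as does compound 2, and the step between them cannot be read because neither value is a true number: the limit of > 4.3 in this assay, at which 2 of the 4 values shown sit.

From the compounds shown here alone, the linking atom and the side chain change together in compound 4, so their separate shares in these steps remain unknown, and 2-ethylbutylamino on the same carbon would separate them. A shorter ether such as methoxy, or an ether carrying the 1-(oxan-4-yl)ethyl group, could give a true number and show how the reading depends on the chain.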